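This account rests on a few compounds, and the source may have more. Where it says the series, first, only, none or still open, it means among the compounds named here.

Among the compounds with values here, compound 1 `COc1cc(-c2cc(C(=O)/C=C/c3ccc(Cl)cc3)nc3cc(-c4ccccc4)nn23)cc(OC)c1OC` is one of three compounds measured in a functional assay on A549 cells (Homo sapiens) for antiproliferative activity, read by MTT assay, with a stated time of 24 h; a higher number here means a weaker inhibitor, a lower number a stronger inhibitor. In this assay compound 1 gives 23800 nM, the highest of the three numbers. Compound 2 `COc1ccc(-c2cc(C(=O)/C=C/c3ccc(Cl)cc3)nc3cc(-c4ccccc4)nn23)cc1OC` differs from it only by hydrogen in place of methoxy on an aromatic carbon and gives 22000 nM; the step of a 1.1-fold lower number from compound 1 to compound 2 (0.03 log units; within the scatter) lies within the scatter. Within the data shown here, compound 3 `COc1ccc(C(=O)/C=C/c2cc(-c3ccc(OC)c(OC)c3)n3nc(-c4ccccc4)cc3n2)cc1OC` carries the same groups in a different arrangement around the shared core and gives 3900 nM; no single structural step connects it to compound 1, so its value shows only that a far lower number occurs in this set.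

Compound 4 `COc1ccc(/C=C/C(=O)c2cc(-c3cc(OC)c(OC)c(OC)c3)n3nc(-c4ccccc4)cc3n2)cc1` differs from compound 1 in one place: methoxy in place of chloro on an aromatic carbon. Among the measured compounds shown here, no measured step touches this position. For the measured compounds named here, the only measured step alters a methoxy on a different aromatic ring, and because that step a 1.1-fold lower number from compound 1 to compound 2 (0.03 log units; within the scatter) stayed within the scatter, it offers no sign that small changes on the aromatic rings of this core move the number far. There is thus no direct guide for a chloro-to-methoxy swap here.

Compound 4 is therefore expected to give about 20000 nM, with a likely range from 7000 nM to 55000 nM. The expected step of a 1.2-fold lower number from compound 1 to compound 4 (0.08 log units; within the scatter) is small and without a clear direction.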

Compound 4, half-maximal inhibitory concentration: 21200 nM
Estimate against measurement, compound 4: 1.1-fold (0.03 log units) below, and the stated range covers the measured number.
By their numbers in this assay, from the lowest: compound 3; then compounds 4, 2 and 1 (each within the scatter of the next).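

Swapping the chloro of the 4-chlorophenyl group for methoxy in this assay gives a 1.1-fold lower number from compound 1 to compound 4 (0.05 log units; within the scatter), so the two compounds cannot be told apart by this measurement. Within the data shown here, this is the first reading at this position, on a six-membered aromatic ring of carbon only and para to a large group, and it shows that chloro and methoxy there give matching numbers on the core of compound 1. Nothing measured alongside these compounds speaks to why the two groups read alike.

As far as these compounds go, only these two groups are seen at this position, so it remains open whether a very different group there, such as an amine or a carboxylic acid, would move the number beyond the scatter or leave it where it is. From the compounds shown here alone, it also remains open whether the same swap from chloro to methoxy, made on compound 2 instead of compound 1, would again give a step this small, since one matched pair cannot establish a rule for the series.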